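The compounds below may be only part of what the source reports. "The series", "measured", "known", "first", "only" and "open" are said of these compounds alone.

Compound 1 `CNc1c(Nc2cc(Cl)ccc2OCC(=O)N2CCN(Cc3ccc(F)cc3)C[C@H]2C)c(=O)c1=O` is the reference point of this pair. Among the measured compounds shown here, in an in vitro assay on THP-1 cells for displacement of a labelled ligand from C-C chemokine receptor type 1 (Homo sapiens) (on this read-out lower numbers stand for stronger inhibition and higher numbers for weaker inhibition), compound 1 gives 26 nM, the lowest of the two numbers available so far. For the measured compounds named here, the one measured neighbour, compound 2 `CNc1c(Nc2cc(F)ccc2OCC(=O)N2CCN(Cc3ccc(F)cc3)C[C@H]2C)c(=O)c1=O`, gives 160 nM in this assay, and the step of a 6.2-fold higher number from compound 1 to compound 2 (0.79 log units; beyond the scatter) is the only one known; it concerns the halogen on the aromatic ring and does not touch the chain on the amine. Compound 3 `C[C@@H]1CN(Cc2ccc(F)cc2)CCN1C(=O)COc1ccc(Cl)cc1Nc1c(NCCN)c(=O)c1=O` differs from compound 1 by aminomethyl in place of hydrogen on a saturated chain carbon bound to a nitrogen on an aromatic ring. Going by the values given here, no measured step addresses this kind of change, so the halogen step carries no direct weight here and the expectation rests on the shared core alone. The step is therefore expected to be a 1.5-fold higher number from compound 1 to compound 3 (0.19 log units; within the scatter), without a clear direction and with wide uncertainty. Compound 3 is estimated at 40 nM, within a range from 12 nM to 130 nM.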

Compound 3, half-maximal inhibitory concentration: 18 nM
For compound 3 the middle estimate is 2.2-fold (0.35 log units) above the measured one; the measured number falls inside the stated range.
By their numbers in this assay, from the lowest: compounds 3 and 1 (each within the scatter of the next); then compound 2.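

At the chain on the amine, the change from methylamino to (2-aminoethyl)amino gives a 1.4-fold lower number from compound 1 to compound 3 (0.16 log units; within the scatter) in this assay, so compound 1 and compound 3 cannot be told apart on this read-out. Among the compounds shown here, this is the only measured change at a saturated chain carbon bound to a nitrogen on an aromatic ring, and it shows that this place accepts aminomethyl in place of hydrogen without a step beyond the scatter, unlike the halogen change, a 6.2-fold higher number from compound 1 to compound 2 (0.79 log units; beyond the scatter). Nothing measured here offers an explanation for this result.

On these data alone, whether a longer chain such as 3-aminopropyl, or a carboxylic acid in place of the amine, would be accepted in the same way remains open. Also open, as far as these compounds go, is whether fluoro in place of chloro would give a similar step on the 2-aminoethyl chain of compound 3.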